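Thiocarbonyl substituent swap in an antiproliferative series

This account rests on a few compounds, and the source may have more. Where it says the series, first, only, none or still open, it means among the compounds named here.

Compound 1 `CN(C(=S)SCc1ccc(C(=O)Nc2ccccc2N)cc1)c1cccnc1` is the lower of the two measured compounds in a functional assay on A-375 cells (Homo sapiens) for antiproliferative activity, read by CCK-8 assay, with a stated time of 72 h, tested at 2 uM (on this read-out higher numbers stand for a stronger effect at the one concentration tested and lower numbers for a weaker effect), where compound 1 gives 26.5%. Compound 2 `N#Cc1ccc(N2CCN(C(=S)SCc3ccc(C(=O)Nc4ccccc4N)cc3)CC2)cc1` gives 41.4% in this assay, a gap beyond the scatter. Compound 3 `Nc1ccccc1NC(=O)c1ccc(CSC(=S)N2CCCC2)cc1` is unmeasured; it differs from compound 1 by pyrrolidin-1-yl in place of methyl(pyridin-3-yl)amino on a thiocarbonyl carbon. Among the measured compounds shown here, no measured pair informs this change, so only a small step is expected, a number 0.5 percentage points lower from compound 1 to compound 3 (within the scatter), with no direction beyond the scatter assumed. For compound 3 the estimated value in this assay is 26%, within the range 12% to 42%.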

Compound 3, a percentage reported as inhibition, at one concentration (the size of the read-out at that concentration, not a potency): 30.2%
The estimate for compound 3 lay 4.2 percentage points below the measured number, within the range that was stated.
By their numbers in this assay, from the lowest: compounds 1 and 3 (each within the scatter of the next); then compound 2.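

Read in this assay the change to pyrrolidin-1-yl from methyl(pyridin-3-yl)amino on a thiocarbonyl carbon gives a number 3.7 percentage points higher from compound 1 to compound 3 (within the scatter) and is the first single-place step in the series. At this position, a five-membered non-aromatic ring can thus replace the six-membered aromatic ring of compound 1 without a shift beyond the scatter at the one concentration tested. No measured evidence bears on this result. From the compounds shown here alone, whether piperidin-1-yl, morpholin-4-yl or dimethylamino on the same carbon would behave alike remains open. Also open, going by these compounds, is whether compound 1 and compound 3 would match in potency across a range of concentrations.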